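Fluorine for Chlorine on the Benzyl Arm

The source may hold more compounds than are shown below. What is called first, only, known or untested is meant among the compounds shown, and "the series" means these compounds.

Compound 1 `CCCn1c(=O)c2nc(-c3cnn(Cc4cc(Cl)ccc4Cl)c3)[nH]c2n(CCC)c1=O` carries a 2,5-dichlorobenzyl group on the shared core. In an in vitro assay on HEK293 cells for displacement of a labelled ligand from adenosine receptor A2b (Homo sapiens) (on this read-out lower numbers stand for stronger inhibition and higher numbers for weaker inhibition), compound 1 gives 29 nM. Of the two numbers that were obtained, this is the higher one; the nearest is compound 2 `CCn1c(=O)c2nc(-c3cnn(Cc4ccccc4)c3)[nH]c2n(CC)c1=O`, which in this assay gives 19 nM, a gap that lies within the usual scatter of such measurements. Compound 3 `CCCn1c(=O)c2nc(-n3cccn3)[nH]c2n(CCC)c1=O` lacks the benzyl-bearing group altogether, and in this assay compound 3 reaches only a limit, > 5800 nM. This is the limit of > 5800 nM in this assay, at which 1 of the 3 values shown sits, and not a number.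

Compound 4 `CCCn1c(=O)c2nc(-c3cnn(Cc4cc(F)ccc4Cl)c3)[nH]c2n(CCC)c1=O` differs from compound 1 in a single exchange: fluoro in place of chloro on an aromatic carbon. The 2,5-dichlorobenzyl of compound 1 thus becomes a 2-chloro-5-fluorobenzyl. Going by the values given here, no measured pair in this set differs by this exchange alone, so the size of the step cannot be read from the data. Compound 1 at 29 nM and compound 2 at 19 nM sit within the scatter of each other although they differ in more than one halogen. The step expected from compound 1 to compound 4 is a 1.2-fold higher number from compound 1 to compound 4 (0.08 log units; within the scatter), which is to say none beyond the scatter. For compound 4 in this assay the estimated inhibition constant is 35 nM, with a range from 14 nM to 90 nM.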

Compound 4, inhibition constant: 4800 nM
Estimate against measurement, compound 4: 140-fold (2.14 log units) below, outside the stated range (above it).
By their numbers in this assay, from the lowest: compounds 2 and 1 (each within the scatter of the next); then compound 4. At a limit, above all of these: compound 3.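

The exchange of fluoro for chloro on an aromatic carbon, meta to a large group and para to a chloro group, swaps one heavy atom for one, with no hydrogen-bond donor, acceptor or net charge on either side, and in this assay it still gives a 170-fold higher number from compound 1 to compound 4 (2.22 log units; beyond the scatter). Going by these compounds alone, this is the first reading of a single change in the set, and it shows that on the shared core the 2,5-dichlorobenzyl and the 2-chloro-5-fluorobenzyl are far from interchangeable, which the earlier compounds, none of them differing in one place, could not show. Compound 3 holds the only limit in the set, which is a limit and not a number, and the step carries the reading toward that upper end of the assay: the limit of > 5800 nM in this assay, at which 1 of the 4 values shown sits.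

As far as these compounds go, what remains open is whether this steep rise belongs to fluoro itself or would follow any replacement of this chloro, which a bromo, a methyl, a methoxy or plain hydrogen on the same carbon would help to separate. The compounds shown also leave open whether the same exchange has a step of this size with ethyl chains on the core in place of propyl chains, or on the other chloro-bearing carbon.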